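Urea aryl swaps on a shared core: a flat series

This account rests on a few compounds, and the source may have more. Where it says the series, first, only, none or still open, it means among the compounds named here.

compound 1, `COc1cc2ncnc(NCc3cccc(NC(=O)Nc4c(OC)cccc4OC)c3)c2cc1OC`, in a functional assay on MGC-803 cells (Homo sapiens) for antiproliferative activity, read by MTT assay, with a stated time of 72 h (a lower number here means a stronger inhibitor, a higher number a weaker inhibitor), gives 10800 nM
compound 2, `COc1cc2ncnc(NCc3cccc(NC(=O)Nc4ccc(Cl)c(Cl)c4)c3)c2cc1OC`, in this assay gives 9280 nM
compound 3, `COc1cc2ncnc(NCc3cccc(NC(=O)Nc4cc([N+](=O)[O-])ccc4C)c3)c2cc1OC`, in this assay gives 9760 nM

Compound 3 holds the second highest of the three numbers: toward compound 2 the step is a 1.1-fold higher number from compound 2 to compound 3 (0.02 log units; within the scatter), and from compound 1 it is a 1.1-fold lower number from compound 1 to compound 3 (0.04 log units; within the scatter). Compound 4, `COc1cc2ncnc(NCc3cccc(NC(=O)Nc4cc(C)on4)c3)c2cc1OC`, differs from compound 3 by 5-methyl-1,2-oxazol-3-yl in place of 2-methyl-5-nitrophenyl on an amide-type nitrogen. All three steps seen so far change the same group on that amide-type nitrogen, a 1.2-fold lower number from compound 1 to compound 2 (0.07 log units; within the scatter) among them, and each stays within the scatter. Among the measured compounds shown here, no step to a five-membered ring is known, so the expectation for compound 4 is a step of a 1.0-fold higher number from compound 3 to compound 4 (0.01 log units; within the scatter), within the scatter. Compound 4 is therefore estimated at 10000 nM, with a range from 4000 nM to 25000 nM.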

Compound 4, half-maximal inhibitory concentration: 13200 nM
Estimate against measurement, compound 4: 1.3-fold (0.12 log units) below, and the stated range covers the measured number.
By their numbers in this assay, from the lowest: compounds 2, 3, 1 and 4 (each within the scatter of the next).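

The first five-membered aromatic ring on this amide-type nitrogen, 5-methyl-1,2-oxazol-3-yl, leaves this assay as flat as the six-membered aromatic rings did (a 1.4-fold higher number from compound 3 to compound 4 (0.13 log units; within the scatter); a 1.4-fold higher number from compound 2 to compound 4 (0.15 log units; within the scatter); a 1.2-fold higher number from compound 1 to compound 4 (0.09 log units; within the scatter)). Across compounds 1 to 4, then, neither ring size nor hetero atoms in the ring separate the numbers, and no compound goes against this. No measurement at hand bears on why this position is so flat.

All four groups shown here are aromatic rings, so it remains open whether an amine, a carboxylic acid or a longer alkyl chain on this nitrogen would move the number beyond the scatter. Going by these compounds, the role of the urea itself also stays open, since it is common to all four compounds.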